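Lengthening an Ester Chain on Two Sulfonamide Cores

The source may report more compounds than this note shows. Statements on the series, on what has been measured and on what is new or still open speak of the compounds shown alone.

Compound 1 `CCOC(=O)c1ccc(S(N)(=O)=O)cc1` and compound 2 `CCCOC(=O)c1ccc(S(N)(=O)=O)cc1` share one core and differ in a single place: methyl in place of hydrogen on a saturated chain carbon, two bonds along the chain from an oxygen next to a carbonyl group. In a physicochemical assay for lipophilicity (on this read-out higher numbers stand for higher lipophilicity and lower numbers for lower lipophilicity), compound 1 gives 1.17, and compound 2 gives 1.75, so the step is a number 0.58 log units higher from compound 1 to compound 2 (beyond the scatter). Compound 3 `CCCOC(=O)c1ccccc1S(N)(=O)=O` carries the same propyl ester on a different core; the difference between the two cores is not broken down here. In this assay compound 3 gives 1.49, which sits near the value of compound 2 and above that of compound 1.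

Compound 4 `CCCCOC(=O)c1ccccc1S(N)(=O)=O` has not yet been measured. It differs from compound 3 in one place: methyl in place of hydrogen on a saturated chain carbon, three bonds along the chain from an oxygen next to a carbonyl group. This is the same kind of change as that from compound 1 to compound 2, though here the entering methyl stands three bonds along the chain from an oxygen next to a carbonyl group rather than two. The step from compound 3 to compound 4 in this assay is expected to be a number 0.53 log units higher from compound 3 to compound 4 (beyond the scatter), close in size to the earlier one, because the measured step of a number 0.58 log units higher from compound 1 to compound 2 (beyond the scatter) came from the same kind of change. Compound 4 is therefore estimated at 2.02, with a likely range from 1.72 to 2.32.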

Compound 4, partition coefficient: 2.01
For compound 4 the middle estimate is 0.01 log units above the measured one; the range from low to high includes it.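

In this assay the new step is a number 0.52 log units higher from compound 3 to compound 4 (beyond the scatter), close in size to the earlier step, a number 0.58 log units higher from compound 1 to compound 2 (beyond the scatter), so in these two cases the same kind of change carried over from one core to the other. This is not a general rule: it rests on a single pair for each core, and the two pairs also differ in where the methyl enters, two bonds along the chain from the oxygen in one pair and three in the other, so the influence of the core cannot be separated from that of the place on the chain. Nothing given here explains why the two steps come out alike.

The compounds shown leave open whether propyl to butyl gives a step of this size on the core of compound 1, and whether a longer chain, such as pentyl, continues the rise on either core. They also leave open how an amine or a carboxylic acid would compare with the methyl on these chains.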